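The source may report more compounds than this note shows. Statements on the series, on what has been measured and on what is new or still open speak of the compounds shown alone.

Working notes on the step from compound 2 to compound 3.

Compound 2 `O=c1c(Cc2coc3cccc(OCc4ccccc4)c3c2=O)coc2ccccc12` stands at > 10000 nM in a functional assay on MDA-MB-231 cells (Homo sapiens) for antiproliferative activity, read by XTT assay (a lower number here means a stronger inhibitor, a higher number a weaker inhibitor), which is a limit of the assay and not a measured number. Compound 1 `CC(C)CCOc1cccc2occ(Cc3coc4ccccc4c3=O)c(=O)c12` stands at > 10000 nM in this assay, likewise a limit. Within the data shown here, the one measured step in the set, a step that the two limits leave unreadable from compound 1 to compound 2, is therefore unreadable in size and direction, since the limit of > 10000 nM in this assay, at which 2 of the 2 values shown sit, is all the pair shows. Among the measured compounds shown here, nothing in the numbers so far separates compound 1 from compound 2.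

Compound 3 `COc1cccc2occ(Cc3coc4ccccc4c3=O)c(=O)c12` is not yet measured. It differs from compound 2 by hydrogen in place of phenyl on a saturated chain carbon bound to an oxygen on an aromatic ring. For the measured compounds named here, no measured step bears readably on this change: the step from compound 1 to compound 2 is the only neighbour, and it cannot be sized because the limit of > 10000 nM in this assay, at which 2 of the 2 values shown sit, holds both of its ends. With the shared core untouched and both measured values at the limit, the most likely outcome for compound 3 is a further limit rather than a number. Compound 3 is expected at 15000 nM in this assay, in the range 5000 nM to 50000 nM. The expected step is a step that the limit leaves unreadable from compound 2 to compound 3, that is, none beyond the scatter.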

Compound 3, half-maximal inhibitory concentration: > 10000 nM
Compound 3 was reported as a limit; the forecaster's own chance of this, stated with the estimate: 80%; the middle value is on the limit's open side.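

No step can be read between compound 1, compound 2 and compound 3, since the new result for compound 3 is again a limit and not a number: the limit of > 10000 nM in this assay, at which 3 of the 3 values shown sit.

The compounds shown leave open whether any group at this place on the shared core gives a measured number in this assay, and how compound 1, compound 2 and compound 3 would rank.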